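The source may hold more compounds than are shown below. What is called first, only, known or untested is meant among the compounds shown, and "the series" means these compounds.

Going by the values given here, in a functional assay on HL-60 cells (Homo sapiens) for antiproliferative activity, with a stated time of 24 h (on this read-out lower numbers stand for stronger inhibition and higher numbers for weaker inhibition), compound 1 `NC(=O)c1c(NC(=O)c2ccccc2Cl)sc2c1CCN(Cc1ccc(Cl)cc1Cl)C2` gives 8010 nM, the lower of the two numbers known so far; compound 2 `Cc1ccc(C(=O)Nc2sc3c(c2C(N)=O)CCN(Cc2ccc(Cl)cc2Cl)C3)cc1` gives 19900 nM, and the only measured step, a 2.5-fold higher number from compound 1 to compound 2 (0.40 log units; beyond the scatter), concerns the group on the carbonyl carbon. Compound 3 `NC(=O)c1c(NC(=O)c2ccccc2Cl)sc2c1CCN(C(=O)Nc1c(Cl)cccc1Cl)C2` differs from compound 1 at a different place: (2,6-dichlorophenyl)carbamoyl in place of 2,4-dichlorobenzyl on an amine nitrogen in a ring. Among the compounds with values here, no measured step touches that place, so there is no ground for expecting a change in this assay beyond the scatter in either direction, and the estimate rests on compound 1 alone. Compound 3 is therefore expected to give about 10000 nM, within 3000 nM to 40000 nM, a step of a 1.2-fold higher number from compound 1 to compound 3 (0.10 log units; within the scatter).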

Compound 3, half-maximal inhibitory concentration: 17700 nM
The estimate for compound 3 lay 1.8-fold (0.25 log units) below the measured number; the range from low to high includes it.
By their numbers in this assay, from the lowest: compound 1; then compounds 3 and 2 (each within the scatter of the next).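

The amine nitrogen in the ring is a second place that responds in this assay: the change there gives a 2.2-fold higher number from compound 1 to compound 3 (0.34 log units; beyond the scatter), a modest step. Here, the (2,6-dichlorophenyl)carbamoyl group, with its hydrogen-bond donor and acceptor, does not give a lower number than 2,4-dichlorobenzyl. Nothing measured here bears on why the number rises.

This single change alters both the link to the nitrogen and the places of the chlorines, and the compounds shown cannot separate the two. They leave open how a 2,6-dichlorobenzyl group or a plain acetyl group on that nitrogen would compare.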